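This account rests on a few compounds, and the source may have more. Where it says the series, first, only, none or still open, it means among the compounds named here.

Measured in an assay for binding affinity to dual specificity mitogen-activated protein kinase kinase 4 (Homo sapiens), read by KINOMEscan, tested at 100 nM; a lower number here means a stronger effect, a higher number a weaker effect of the compound at the concentration tested:
compound 1 `CCCS(=O)(=O)Nc1ccc(F)c(C(=O)c2n[nH]c3ncc(-c4cccc(N(C)C)c4)cc23)c1F`: 26%
compound 2 `CCCS(=O)(=O)Nc1ccc(F)c(C(=O)c2n[nH]c3ncc(-c4cccc(C(F)(F)F)c4)cc23)c1F`: 57%

Among the measured compounds shown here, compound 2 gives the highest of these two numbers; the one measured step leading to it is a number 31 percentage points higher from compound 1 to compound 2 (beyond the scatter), a large step in this assay. Compound 3 `CCCS(=O)(=O)Nc1ccc(F)c(C(=O)c2n[nH]c3ncc(-c4ccc(S(=O)(=O)NC)cc4)cc23)c1F` differs from compound 2 in one place: 4-(methylsulfamoyl)phenyl in place of 3-(trifluoromethyl)phenyl on an aromatic carbon. The step from compound 1 to compound 2 bears on this only loosely, as it replaced a different group at the same aromatic carbon, so the direction for compound 3 is uncertain. Compound 3 is expected to land at 45%, between 15% and 85%, an expected step of a number 12 percentage points lower from compound 2 to compound 3 (beyond the scatter).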

Compound 3, a percentage reported as activity, at one concentration (the size of the read-out at that concentration, not a potency): 1.2%
The estimate for compound 3 lay 43.8 percentage points above the measured number; measured number below the stated range.
By their numbers in this assay, from the lowest: compound 3; then compound 1; then compound 2.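

In this assay this aromatic carbon accepts 4-(methylsulfamoyl)phenyl with a number 55.8 percentage points lower from compound 2 to compound 3 (beyond the scatter) and with a number 24.8 percentage points lower from compound 1 to compound 3 (beyond the scatter) so compound 3 shows the strongest effect of the three, and the group here can move the read-out much further than the first pair showed. Unlike 3-(trifluoromethyl)phenyl, the entering group carries a hydrogen-bond donor and hydrogen-bond acceptors. No measurement here explains the drop. The change alters both the group and its place on the phenyl ring, so the two cannot be separated. From the compounds shown here alone, how a carboxylic acid or a primary amine would read on that ring remains open.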